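The compounds below may be only part of what the source reports. "The series", "measured", "known", "first", "only" and "open" are said of these compounds alone.

Measured in an assay (strain Wistar) for inhibition of Amine oxidase [flavin-containing] A (Rattus norvegicus); on this read-out higher numbers stand for weaker inhibition and lower numbers for stronger inhibition:
compound 1, `NC(=O)[C@@H]1CCCN1c1cc(=O)oc2cc(OCc3ccccc3)ccc12`, 99800 nM.
compound 2, `NC(=O)Cc1cc(=O)oc2cc(OCc3cccnc3)ccc12`, 21000 nM.
compound 3, `O=C(Cc1cc(=O)oc2cc(OCc3cccc(Cl)c3)ccc12)NCc1ccccc1`, reported only as a limit of the assay, > 100000 nM.

Of the two compounds that give a number in this assay, compound 1 stands highest; the number for compound 2 is lower, and the gap between them is beyond the usual scatter. Compound 3 sits at the limit of > 100000 nM in this assay, at which 1 of the 3 values shown sits, so its value is a limit and not a number, and it sets no order against the other two.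

Compound 4, `CNCc1cc(=O)oc2cc(OCc3ccccc3)ccc12`, shares the core of compound 1 and differs from it in one place: (methylamino)methyl in place of 2-carbamoylpyrrolidin-1-yl on an aromatic carbon. Among the compounds with values here, no measured pair in this set makes the same change, so the size of the step can only be estimated from where compound 1 stands. The small basic side chain that enters is unlike anything among the measured compounds, and the weak number of compound 1 leaves room in both directions. The step from compound 1 to compound 4 is expected to be a 3.3-fold lower number from compound 1 to compound 4 (0.52 log units; beyond the scatter), a moderate move towards stronger inhibition. In this assay compound 4 is therefore estimated at 30000 nM, within a range from 5000 nM to 100000 nM.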

Compound 4, half-maximal inhibitory concentration: 15400 nM
For compound 4 the middle estimate is 1.9-fold (0.29 log units) above the measured one; the range from low to high includes it.
By their numbers in this assay, from the lowest: compounds 4 and 2 (each within the scatter of the next); then compound 1. At a limit, above all of these: compound 3.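

In this assay, within the data shown here, the group on the aromatic carbon opposite the ring oxygen proves to matter: (methylamino)methyl in place of 2-carbamoylpyrrolidin-1-yl gives a 6.5-fold lower number from compound 1 to compound 4 (0.81 log units; beyond the scatter), the only change in the set that can be read at a single place on the shared core. The step also shows that neither the five-membered non-aromatic ring, nor the amide, nor the defined stereocentre of the departing group is required for inhibition, since compound 4, which has a smaller open chain and none of the three, still gives 15400 nM. Nothing measured here accounts for the direction or size of this step.

With the ring, the amide and the chain all changing at once, the compounds shown leave open which of these differences carries the step; a plain pyrrolidin-1-yl group or an aminomethyl group at the same place would begin to separate them. Also open, from the compounds shown here alone, is whether a dimethylaminomethyl group or a longer aminoethyl chain would move the number further, and whether the step would hold on a core with a different benzylic ether.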